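The compounds below may be only part of what the source reports. "The series", "measured", "known", "first", "only" and "open" are said of these compounds alone.

Compound 1 `C=Cc1cc(C(F)(F)F)cc(C(F)(F)F)c1`: > 50 h
Compound 2 `O=C(CBr)c1cc(C(F)(F)F)cc(C(F)(F)F)c1`: < 0.017 h

In an ADME assay for pharmacokinetics, read by LC-MS, in phosphate buffer, with a stated time of 72 h, at pH 7.4, tested at 250 uM (on this read-out higher numbers stand for a longer-lived compound and lower numbers for a shorter-lived compound), compound 1 gives > 50 h, which is a limit of the assay rather than a number (the limit of > 50 h in this assay, at which 1 of the 2 values shown sits). In this assay compound 2 gives < 0.017 h, likewise a limit of the assay and not a number (the limit of < 0.017 h in this assay, at which 1 of the 2 values shown sits). Compound 2 therefore stands at the short-lived end of the two values shown. Among the compounds with values here, the one measured step, an at least 2900-fold lower number from compound 1 to compound 2 (3.46 log units; beyond the scatter), runs between these two limits. Compound 3 `FC(F)(F)c1cc(C2CO2)cc(C(F)(F)F)c1` has not yet been measured; it differs from compound 2 by oxiran-2-yl in place of (bromomethyl)carbonyl on an aromatic carbon. Within the data shown here, no measured step involves an oxiranyl group, so the only guide is that a (bromomethyl)carbonyl group sits at the short-lived limit while a vinyl group sits at the long-lived one. Compound 3 is expected to move well away from the short-lived limit, a step of an at least 1100-fold higher number from compound 2 to compound 3 (3.07 log units; beyond the scatter). The estimated half-life for compound 3 is 20 h, between 4 h and 50 h.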

Compound 3, half-life: > 50 h
Compound 3: no number, only a limit; the forecaster's own chance of this, stated with the estimate: 25%; at least 2.5-fold (0.39 log units) between middle value and limit.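

Replacing (bromomethyl)carbonyl with oxiran-2-yl on this aromatic carbon gives, in this assay, an at least 2900-fold higher number from compound 2 to compound 3 (3.46 log units; beyond the scatter). The short half-life of compound 2 is therefore not shared by every group at this place, meta to two trifluoromethyl groups: a group with a three-membered ring now stands at the long-lived end, where only vinyl stood before. Compound 1 and compound 3 share one limit of the assay, so the step between them cannot be read and no order of the two can be given: the limit of > 50 h in this assay, at which 2 of the 3 values shown sit.

The compounds shown leave open how long compound 1 and compound 3 last beyond that limit. They also do not separate the carbonyl from the bromine in compound 2, so an acetyl group, which keeps the carbonyl without the bromine, or an amine at this place could fall anywhere on this scale.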